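The compounds below may be only part of what the source reports. "The series", "measured", "known", "first", "only" and "open" are said of these compounds alone.

Compounds 1, 2 and 3 share one core and differ only in the group on the cinnamoyl ring. In a functional assay on CHO cells for inhibition of transient receptor potential cation channel subfamily V member 1 (Homo sapiens) (on this read-out higher numbers stand for weaker inhibition and lower numbers for stronger inhibition), compound 1, `O=C(/C=C/c1ccccc1)Nc1ccc2c(c1)OCCO2`, gives > 4000 nM, a limit of the assay rather than a number. Compound 2, `O=C(/C=C/c1ccc(-c2ccccc2)cc1)Nc1ccc2c(c1)OCCO2`, also stops at the limit > 4000 nM. Compound 3, `O=C(/C=C/c1ccc(F)cc1)Nc1ccc2c(c1)OCCO2`, stands at the limit > 4000 nM as well, so its place among the three cannot be ranked, because of the limit of > 4000 nM in this assay, at which 3 of the 3 values shown sit. The steps a step that the two limits leave unreadable from compound 1 to compound 3 and a step that the two limits leave unreadable from compound 2 to compound 3 touch the same ring position but are unreadable. Compound 4, `O=C(/C=C/c1ccc(C(F)(F)F)cc1)Nc1ccc2c(c1)OCCO2`, differs from compound 3 by trifluoromethyl in place of fluoro on an aromatic carbon. No readable step bears on this change, so compound 4 is expected near the same limit, with the step of a number no higher from compound 3 to compound 4 (the limit leaves the size open) estimated, giving about 4000 nM within 800 nM to 20000 nM.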

Compound 4, half-maximal inhibitory concentration: 100 nM
Estimate against measurement, compound 4: 40-fold (1.60 log units) above; measured number below the stated range.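

At this ring position, trifluoromethyl is the only group shown that gives a measured number in this assay, with an at least 40-fold lower number from compound 3 to compound 4 (1.60 log units; beyond the scatter). The same holds against the two other groups, with an at least 40-fold lower number from compound 2 to compound 4 (1.60 log units; beyond the scatter) and against hydrogen, with an at least 40-fold lower number from compound 1 to compound 4 (1.60 log units; beyond the scatter). The position therefore responds strongly to the group it carries, while the steps among compound 1, compound 2 and compound 3 cannot be read: the limit of > 4000 nM in this assay, at which 3 of the 4 values shown sit.

From the compounds shown here alone, whether a chloro, methoxy or nitrile group at this position would match trifluoromethyl remains open. Going by these compounds, each step has a limit at one end, so its full size also remains open.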